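The source may hold more compounds than are shown below. What is called first, only, known or untested is meant among the compounds shown, and "the series" means these compounds.

Of the compounds shown here, three sharing one core have been measured in an in vitro functional assay on cells for agonist activity at Bombesin receptor subtype-3 (Homo sapiens), read by luminescence and calcium flux; a lower number here means that less compound is needed, a higher number that more compound is needed for the effect. Compound 1 `O=C(O)c1ccccc1-c1ccc(CCc2ncc(CC3CCCCCC3)[nH]2)cc1` gives 88 nM. Compound 2 `N#Cc1cccc(Cc2cnc(CCc3ccc(-c4ccccc4C(=O)O)cc3)[nH]2)c1` gives 812 nM, and compound 3 `O=C(O)c1ccccc1-c1ccc(CCc2ncc(Cc3cccc(F)c3)[nH]2)cc1` gives 159 nM. Among these three numbers compound 3 stands second highest: its step from compound 1 is a 1.8-fold higher number from compound 1 to compound 3 (0.26 log units; within the scatter), and its step from compound 2 is a 5.1-fold lower number from compound 2 to compound 3 (0.71 log units; beyond the scatter).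

Compound 4 `Cc1ccccc1Cc1cnc(CCc2ccc(-c3ccccc3C(=O)O)cc2)[nH]1` has not yet been measured. Its change from compound 3 is 2-methylphenyl in place of 3-fluorophenyl on a saturated chain carbon bound to an aromatic carbon. Among the measured compounds shown here, no measured step makes exactly this swap, so the closest guidance comes from the changes already seen on the same saturated chain carbon: a 1.8-fold higher number from compound 1 to compound 3 (0.26 log units; within the scatter) and a 9.2-fold higher number from compound 1 to compound 2 (0.97 log units; beyond the scatter). One of those stays within the scatter and the other is only modest, which suggests that the ring placed here can be varied without a large change in this assay.

The expected step is therefore small: a 1.3-fold higher number from compound 3 to compound 4 (0.10 log units; within the scatter). Compound 4 is estimated to give 200 nM. For compound 4 the expected range runs from 70 nM to 600 nM.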

Compound 4, half-maximal effective concentration: 127 nM
Estimate against measurement, compound 4: 1.6-fold (0.20 log units) above, within the range that was stated.
By their numbers in this assay, from the lowest: compounds 1, 4 and 3 (each within the scatter of the next); then compound 2.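

In this assay, the 2-methylphenyl group on this saturated chain carbon gives a number that cannot be told apart from that of the 3-fluorophenyl group, a 1.3-fold lower number from compound 3 to compound 4 (0.10 log units; within the scatter), or from that of the cycloheptyl group, a 1.4-fold higher number from compound 1 to compound 4 (0.16 log units; within the scatter). A second aromatic ring now matches the cycloheptyl group, while the 3-cyanophenyl group stands apart, a 6.4-fold lower number from compound 2 to compound 4 (0.81 log units; beyond the scatter), so among these compounds the higher number goes with compound 2 alone rather than with aromatic rings in general. Nothing measured here explains this difference.

The swap from compound 3 to compound 4 changes both the group on the ring and its place there, and these compounds cannot separate those two changes. Also open, on these data alone, is how this position would respond to an amine on the ring or to an open alkyl chain in place of the ring.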